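Swapping Fluoro for Amino on Compound 3

A few compounds are considered here, and "the series" means these few. Any claim that something is new, unique, unknown or untested is made for them only; others in the source may bear on it.

In a functional assay on K562 cells (Homo sapiens) for cytotoxicity, read by trypan blue exclusion, with a stated time of 96 h (on this read-out higher numbers stand for weaker inhibition and lower numbers for stronger inhibition), compound 3 (`COc1ccc(NS(=O)(=O)/C=C/c2c(F)c(F)c(F)c(F)c2F)cc1F`) gives 10000 nM. That value lies within the scatter of compound 1 (`COc1cc(OC)c(/C=C/S(=O)(=O)Nc2cc(N)c(OC)c(N)c2)c(OC)c1`) at 7500 nM. Compound 2 (`COc1ccc(/C=C/S(=O)(=O)Nc2ccc(OC)c(F)c2)cc1`) gives 1000 nM, a lower number beyond the scatter, which means stronger inhibition than compound 3 shows.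

Compound 4 (`COc1ccc(NS(=O)(=O)/C=C/c2c(F)c(F)c(F)c(F)c2F)cc1N`) has amino in place of fluoro on an aromatic carbon, ortho to a methoxy group and meta to a large group: amino in place of fluoro on an aromatic carbon.

Within the data shown here, no measured pair shows this swap on its own, so the expectation rests on limited evidence. Compound 1 carries amino groups and gives 7500 nM, so amino groups alone do not guarantee a low number. Among the measured compounds shown here, compound 2 at 1000 nM shows only that numbers well under that of compound 3 occur in this small set. A moderate gain is therefore expected, with a 5.0-fold lower number from compound 3 to compound 4 (0.70 log units; beyond the scatter) as the estimated step, though a result within the scatter remains possible. For compound 4 the estimated value is 2000 nM, with an expected range from 300 nM to 10000 nM.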

Compound 4, half-maximal inhibitory concentration: 75000 nM
Compound 4: the middle estimate sits 38-fold (1.57 log units) below what was measured; measured number outside the range, above it.
By their numbers in this assay, from the lowest: compound 2; then compounds 1 and 3 (each within the scatter of the next); then compound 4.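

At this aromatic carbon, ortho to a methoxy group, the choice between fluoro and amino clearly matters: in this assay the swap brings a 7.5-fold higher number from compound 3 to compound 4 (0.88 log units; beyond the scatter), which means weaker inhibition. Among these compounds, this is the first single change that can be read in the set, and it shows that the number responds to what sits at this one position. Here, amino does worse than fluoro, though nothing measured in this set explains the loss.

The compounds shown leave open how other groups would behave at this position, such as a hydroxyl, a methyl or a chloro group, and whether any of them would give a lower number than compound 3. They also leave open whether the same swap would have a similar effect on the core of compound 2, which also carries fluoro ortho to a methoxy group.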